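Ring Closure on the Ether Side Chain of Compound 2

The source may hold more compounds than are shown below. What is called first, only, known or untested is meant among the compounds shown, and "the series" means these compounds.

Measured so far in a functional assay on MT2 cells (Homo sapiens) for cytotoxicity, read by MTT assay; on this read-out higher numbers stand for lower toxicity in this test and lower numbers for higher toxicity in this test:

Compound 1 `CCCc1ccc(Nc2nccs2)cc1OCC=C(C)C` gives 23000 nM in this assay.
Compound 2 `CC(C)=CCOc1cc(Nc2nccs2)ccc1C#N` gives 750 nM in this assay.

Going by the values given here, compound 2 holds the lower of the two numbers in this assay, meaning it is the more toxic of the pair; the only measured step, a 31-fold lower number from compound 1 to compound 2 (1.49 log units; beyond the scatter), is large and lies well beyond the scatter. That step concerns a cyano in place of propyl on an aromatic carbon and says nothing about the ether side chain.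

Compound 3 `N#Cc1ccc(Nc2nccs2)cc1OCC1=CCCC1` keeps the cyano group and the shared core of compound 2 and changes only the chain on the oxygen: cyclopent-1-en-1-yl in place of 2-methylprop-1-en-1-yl on a saturated chain carbon bound to an oxygen on an aromatic ring. Among the compounds with values here, no measured step in this assay addresses a change of this kind, so there is no direct precedent for its size or direction. Both groups carry one double bond outside aromatic rings and differ by a single heavy atom, the new one closing a five-membered ring. Within the data shown here, with no step to lean on, the expected change is small, not beyond the scatter.

Compound 3 is therefore estimated at 800 nM in this assay, between 300 nM and 2200 nM, which means an expected step of a 1.1-fold higher number from compound 2 to compound 3 (0.03 log units; within the scatter).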

Compound 3, half-maximal cytotoxic concentration: 1700 nM
For compound 3 the middle estimate is 2.1-fold (0.33 log units) below the measured one; low and high end bracket the measured number.
By their numbers in this assay, from the lowest: compound 2; then compound 3; then compound 1.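

Closing the chain into a ring registers in this assay as a 2.3-fold higher number from compound 2 to compound 3 (0.36 log units; beyond the scatter) on the way to a less toxic reading in this test. Going by these compounds alone, this is the first measured sign that the chain on the oxygen affects the result while the cyano group stays in place: moving from 3-methylbut-2-en-1-yl to (cyclopent-1-en-1-yl)methyl gives a modest step beyond the scatter. That step is much smaller than a 31-fold lower number from compound 1 to compound 2 (1.49 log units; beyond the scatter) at the other changed position, so among these three compounds the swap of propyl for cyano is the larger of the two measured changes. No evidence at hand accounts for the shift in compound 3.

Going by these compounds, it remains open whether the double bond in the ring matters, which a saturated cyclopentylmethyl chain would address, and whether a cyclohexenylmethyl chain, with its six-membered ring, would move the number further in the same direction. On these data alone, it is also open whether the same ring closure would give a step of similar size with propyl in place of the cyano group, on the core of compound 1.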